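The source may hold more compounds than are shown below. What is called first, only, known or untested is meant among the compounds shown, and "the series" means these compounds.

Of the compounds shown here, three have so far been measured in an assay on HEK293 cells for antagonist activity at P2X purinoceptor 7 (Homo sapiens), read by fluorescence, with a stated time of 2 h; a higher number here means a weaker inhibitor, a lower number a stronger inhibitor. Compound 1 `CNC(=O)c1cccc(S(=O)(=O)Oc2ccc(-c3cncn3C3CCN(C(=O)c4ccc([N+](=O)[O-])cc4)CC3)cc2)c1` gives 62 nM in this assay. Compound 2 `CNC(=O)c1cccc(S(=O)(=O)Oc2ccc(-c3cncn3C3CCN(C(=O)c4ccc(N(C)C)cc4)CC3)cc2)c1` gives 25 nM in this assay. Compound 3 `O=C(NC1CC1)c1cccc(S(=O)(=O)Oc2ccc(-c3cncn3C3CCN(C(=O)c4ccc([N+](=O)[O-])cc4)CC3)cc2)c1` gives 152 nM in this assay, the highest of the three numbers.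

Compound 2 differs from compound 1 in a single place (dimethylamino in place of nitro on an aromatic carbon), and this change produced a 2.5-fold lower number from compound 1 to compound 2 (0.39 log units; beyond the scatter). Compound 3 differs from compound 1 at another place (cyclopropyl in place of methyl on an amide-type nitrogen), and that change produced a 2.5-fold higher number from compound 1 to compound 3 (0.39 log units; beyond the scatter). Compound 2 and compound 3 are not joined by a single change, and their numbers simply stand as given.

Compound 4 `CN(C)c1ccc(C(=O)N2CCC(n3cncc3-c3ccc(OS(=O)(=O)c4cccc(C(=O)NC5CC5)c4)cc3)CC2)cc1` has not yet been measured. Among the measured compounds shown here, it stands to compound 3 as compound 2 stands to compound 1: the difference dimethylamino in place of nitro on an aromatic carbon is the same change, at the same place on the same kind of ring, as the one from compound 1 to compound 2, while the two cores differ in the way already set out between compound 1 and compound 3. For the measured compounds named here, only one earlier example of this change exists, so the expectation rests on a single step. Going by the values given here, the step from compound 3 to compound 4 is therefore estimated to be a 2.5-fold lower number from compound 3 to compound 4 (0.40 log units; beyond the scatter), a size chosen because a 2.5-fold lower number from compound 1 to compound 2 (0.39 log units; beyond the scatter) is the only guide available. Compound 4 is accordingly expected to give about 60 nM in this assay, with an estimated range from 30 nM to 120 nM.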

Compound 4, half-maximal inhibitory concentration: 0.49 nM
The estimate for compound 4 lay 120-fold (2.09 log units) above the measured number; the whole stated range lies above it.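

In this assay, putting dimethylamino in place of nitro did not carry over from one core to the other at a constant size; on the cyclopropyl amide core it gave a 310-fold lower number from compound 3 to compound 4 (2.49 log units; beyond the scatter), far larger than the step on the methyl amide core: the same change on two cores in this assay, a 2.5-fold lower number (0.39 log units; beyond the scatter) from compound 1 to compound 2 and a 310-fold lower number (2.49 log units; beyond the scatter) from compound 3 to compound 4, 130-fold (2.10 log units) apart, beyond the scatter of two such steps. The cyclopropyl-for-methyl change behaved differently again, raising the number with nitro on the ring but giving a 51-fold lower number from compound 2 to compound 4 (1.71 log units; beyond the scatter) with dimethylamino there, so even its direction depended on the group at the other end of the molecule: the same change on two cores in this assay, a 2.5-fold higher number (0.39 log units; beyond the scatter) from compound 1 to compound 3 and a 51-fold lower number (1.71 log units; beyond the scatter) from compound 2 to compound 4, 130-fold (2.10 log units) apart, beyond the scatter of two such steps. This shows that the two changes do not add up independently across these compounds and that only the direction of the dimethylamino change held on both cores, but it rests on a single set of four compounds and does not show why the two changes combine in this way or whether the same holds on any other core.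

The compounds shown leave open whether the large gain belongs to dimethylamino itself or would also appear with a primary amine or a methoxy group at that place. They also leave open whether an ethyl or cyclobutyl group on the amide nitrogen would pair with dimethylamino as cyclopropyl does.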